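The source may report more compounds than this note shows. Statements on the series, on what has been measured and on what is new or still open speak of the compounds shown alone.

Measured compounds:
compound 1, `COc1ncnc(Nc2ccc(C#N)c(OCC=C(C)C)c2)n1`, 42000 nM
compound 2, `COc1nc(Nc2ccc(C#N)c(OCC=C(C)C)c2)nc(OC)n1`, > 100000 nM
compound 3, `C/C=C/COc1cc(Nc2ncccn2)ccc1Cl`, 31000 nM

All three were tested in an ADME assay on MT2 cells (Homo sapiens) for cytotoxicity; on this read-out higher numbers stand for lower toxicity in this test and lower numbers for higher toxicity in this test. Compound 1 gives 42000 nM. The value of compound 2 is a limit of the test, not a number: the limit of > 100000 nM in this assay, at which 1 of the 3 values shown sits. Compound 3 gives 31000 nM, and this value and that of compound 1 lie within the scatter of each other. How the core of compound 3 differs from the core of compound 1 is not broken down here.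

Compound 1 and compound 2 differ in one place: methoxy in place of hydrogen on an aromatic carbon. This change produced an at least 2.3-fold higher number from compound 1 to compound 2 (0.37 log units; beyond the scatter).

Compound 4, `C/C=C/COc1cc(Nc2nccc(OC)n2)ccc1Cl`, is compound 3 with the same kind of change: methoxy in place of hydrogen on an aromatic carbon. The surroundings are not the same: in compound 2 the methoxy sits between two ring nitrogen atoms and meta to a methoxy group, in compound 4 it sits next to the ring nitrogen. The step seen from compound 1 to compound 2, an at least 2.3-fold higher number from compound 1 to compound 2 (0.37 log units; beyond the scatter), is the only basis for an expectation. The expected step is a 2.3-fold higher number from compound 3 to compound 4 (0.35 log units; beyond the scatter). Compound 4 is therefore estimated at 70000 nM, with a likely range from 30000 nM to 150000 nM.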

Compound 4, half-maximal cytotoxic concentration: 17000 nM
Estimate against measurement, compound 4: 4.1-fold (0.61 log units) above; the measured number lies below the stated range.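

On the core of compound 3, methoxy in place of hydrogen on an aromatic carbon gave a 1.8-fold lower number from compound 3 to compound 4 (0.26 log units; within the scatter) in this assay, so compound 3 and compound 4 cannot be told apart in this test. Set beside the earlier step, the same change did not carry over from one core to the other: the same change on two cores in this assay, an at least 2.3-fold higher number (0.37 log units; beyond the scatter) from compound 1 to compound 2 and a 1.8-fold lower number (0.26 log units; within the scatter) from compound 3 to compound 4, at least 4.3-fold (0.63 log units) apart, beyond the scatter of two such steps. This does not show why the two steps differ, and the first step has no known upper end, as compound 2 holds only a limit of the test and not a number: the limit of > 100000 nM in this assay, at which 1 of the 4 values shown sits.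

Within the data shown here, it remains open which of the differences between the two cores goes with this gap, as each core contributes only one pair. From the compounds shown here alone, it is also open whether another group in the same place, such as an amine or an ethoxy chain, would follow the first step, the second, or neither.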